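From 2-fluorophenyl to 4-fluorophenyl on the amide-type nitrogen

The source may hold more compounds than are shown below. What is called first, only, known or untested is meant among the compounds shown, and "the series" means these compounds.

Measured so far in an ADME assay on MT4 cells (Homo sapiens) for cytotoxicity, read by MTT assay, with a stated time of 4 days (on this read-out lower numbers stand for higher toxicity in this test and higher numbers for lower toxicity in this test), across three compounds:
- compound 1 `Cc1cccc(NC(=O)CS(=O)(=O)c2nccc(Oc3c(C)cc(C#N)cc3C)n2)c1` gives 25700 nM in this test
- compound 2 `COc1ccc(NC(=O)CS(=O)(=O)c2nccc(Oc3c(C)cc(C#N)cc3C)n2)cc1` gives 5110 nM in this test
- compound 3 `Cc1cc(C#N)cc(C)c1Oc1ccnc(S(=O)(=O)CC(=O)Nc2ccccc2F)n1` gives 28400 nM in this test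

Compound 3 gives 28400 nM in this assay and sits level with compound 1 at the upper end of the three numbers. The data show one small step (a 1.1-fold higher number from compound 1 to compound 3 (0.04 log units; within the scatter)) and one larger step (a 5.6-fold higher number from compound 2 to compound 3 (0.74 log units; beyond the scatter)) into it.

Compound 4 `Cc1cc(C#N)cc(C)c1Oc1ccnc(S(=O)(=O)CC(=O)Nc2ccc(F)cc2)n1` differs from compound 3 by one swap (4-fluorophenyl in place of 2-fluorophenyl on an amide-type nitrogen), 4-fluorophenyl in place of 2-fluorophenyl on an amide-type nitrogen. Among the compounds with values here, no measured compound carries 4-fluorophenyl, so no step tests this swap directly. The nearest guide is compound 2, the 4-methoxyphenyl member, with its modest step (a 5.0-fold lower number from compound 1 to compound 2 (0.70 log units; beyond the scatter)) towards a lower number. One case is thin evidence, so only part of that move is expected, perhaps not beyond the scatter. The expected change is estimated as a small one (a 1.8-fold lower number from compound 3 to compound 4 (0.25 log units; within the scatter)) on this read-out. Compound 4 is estimated at 16000 nM (expected range 5500 nM to 38000 nM) in this assay on this reasoning.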

Compound 4, half-maximal cytotoxic concentration: 26100 nM
Beside the measured number, compound 4's estimate is 1.6-fold (0.21 log units) below it; measured number inside the range.
By their numbers in this assay, from the lowest: compound 2; then compounds 1, 4 and 3 (each within the scatter of the next).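

In this assay, the two fluorophenyl groups on the amide-type nitrogen cannot be told apart (a 1.1-fold lower number from compound 3 to compound 4 (0.04 log units; within the scatter)), so the place of the fluoro on this ring makes no visible difference between these two compounds. The low number of compound 2 does not go with the 4-substituted phenyl as such: fluoro in place of methoxy on the same aromatic carbon gives a 5.1-fold higher number from compound 2 to compound 4 (0.71 log units; beyond the scatter), while 4-fluorophenyl stands level with 3-methylphenyl (a 1.0-fold higher number from compound 1 to compound 4 (0.01 log units; within the scatter)), which ties that low number to the methoxy group in this small set. No supporting measurement bears on why the numbers fall this way.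

As far as these compounds go, it remains open whether an amine or a carboxylic acid in place of the fluoro on that aromatic carbon would stay with compound 4 or move towards compound 2. From the compounds shown here alone, whether a longer chain than methoxy, such as ethoxy, would go further is equally open.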